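This account rests on a few compounds, and the source may have more. Where it says the series, first, only, none or still open, it means among the compounds named here.

Measured so far:
compound 1, `COc1cccc(/C=C/C(=O)c2c(OC)cc(OC)cc2OC)c1`: 5900 nM
compound 2, `COc1cc(OC)c(C(=O)/C=C/c2ccc(Cl)cc2)c(OC)c1`: 6500 nM
compound 3, `COc1cccc(/C=C/C(=O)c2c(O)cc(OC)cc2OC)c1`: 9000 nM

All three numbers come from a functional assay on RL cells (Homo sapiens) for cytotoxicity, with a stated time of 48 h; a lower number here means a stronger inhibitor, a higher number a weaker inhibitor. Compound 1 stands with the other two inside the usual scatter: a 1.1-fold higher number from compound 1 to compound 2 (0.04 log units; within the scatter) and a 1.5-fold higher number from compound 1 to compound 3 (0.18 log units; within the scatter), neither reaching beyond it. Nothing in this set separates the three.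

Compound 4 `COc1cc(OC)c(C(=O)/C=C/c2ccccc2)c(OC)c1` has not yet been measured in this assay. It differs from compound 1 in one place: hydrogen in place of methoxy on an aromatic carbon. The methoxy that sits on the aromatic ring meta to a large group is taken away, so that 3-methoxyphenyl becomes phenyl.

Among the compounds with values here, two measured steps bear on this. The first, 4-chlorophenyl in place of 3-methoxyphenyl on the same ring, gives a 1.1-fold higher number from compound 1 to compound 2 (0.04 log units; within the scatter). The second, hydrogen in place of methyl on an oxygen on an aromatic ring, gives a 1.5-fold higher number from compound 1 to compound 3 (0.18 log units; within the scatter). Within the data shown here, both lie within scatter, neither is the exact change, and no step that removes this methoxy has been measured. The expectation is therefore a step from compound 1 to compound 4 of no size beyond the scatter, a 1.2-fold higher number from compound 1 to compound 4 (0.07 log units; within the scatter). Compound 4 is estimated at 7000 nM, in the range 3500 nM to 14000 nM.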

Compound 4, half-maximal inhibitory concentration: 6900 nM
Beside the measured number, compound 4's estimate is 1.0-fold (0.01 log units) above it; measured number inside the range.
By their numbers in this assay, from the lowest: compounds 1, 2, 4 and 3 (each within the scatter of the next).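

Taking the methoxy off this aromatic carbon, the direct test of the position in this assay, gives a 1.2-fold higher number from compound 1 to compound 4 (0.07 log units; within the scatter), so the 3-methoxyphenyl to phenyl change leaves the number inside the scatter and the methoxy is not required to hold it in this range. Hydrogen in place of chloro gives a 1.1-fold higher number from compound 2 to compound 4 (0.03 log units; within the scatter), which means that phenyl, 3-methoxyphenyl and 4-chlorophenyl, the three forms of this ring now in hand, cannot be told apart in this assay and that neither the methoxy nor the chloro has a separable contribution here. No supporting data bear on why these ring changes leave the number so little altered.

Still open, as far as these compounds go, is whether any group at this ring can carry the number beyond the scatter, for instance an amine or a carboxylic acid, which differ more from hydrogen than the methoxy and chloro do. Equally open, from the compounds shown here alone, is whether the flat response persists when the change falls elsewhere on the shared core, such as a longer chain in place of a methoxy on the other aromatic ring.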